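This account rests on a few compounds, and the source may have more. Where it says the series, first, only, none or still open, it means among the compounds named here.

Compound 1 `CC(C)(C)OC(=O)NCCCCNC(=O)CN1CN(c2ccccc2)C2(CCN(C(=O)c3ccc(C(C)(C)C)cc3)CC2)C1=O` gives "not determined" (no result reported) in an assay on HEK293 cells for displacement of a labelled ligand from NPC1-like intracellular cholesterol transporter 1 (Homo sapiens); on this read-out lower numbers stand for stronger inhibition and higher numbers for weaker inhibition. Among the compounds with values here, compound 2 `CCC1CCCN(C(=O)CN2CN(c3ccccc3)C3(CCN(C(=O)c4ccc(C(C)(C)C)cc4)CC3)C2=O)C1` is the only compound with a number: in this assay compound 2 gives 3900 nM, so it stands alone on this read-out. Compound 3 `CC(C)(C)c1ccc(C(=O)N2CCC3(CC2)C(=O)N(CC(=O)NCCCCN)CN3c2ccccc2)cc1` differs from compound 2 by (4-aminobutyl)amino in place of 3-ethylpiperidin-1-yl on a carbonyl carbon. Within the data shown here, no measured pair shows such an exchange, so the step is expected to be small, a 1.3-fold higher number from compound 2 to compound 3 (0.11 log units; within the scatter), and may well lie within the scatter. For compound 3 the estimate in this assay is 5000 nM, within 1500 nM to 15000 nM.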

Compound 3, half-maximal inhibitory concentration: 14500 nM
Compound 3: the middle estimate sits 2.9-fold (0.46 log units) below what was measured; measured number inside the range.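

The group on this carbonyl carbon can change without abolishing inhibition, but the change is not neutral: in this assay, replacing 3-ethylpiperidin-1-yl with (4-aminobutyl)amino gives a 3.7-fold higher number from compound 2 to compound 3 (0.57 log units; beyond the scatter) as a modest weakening. This single exchange removes a ring and adds hydrogen-bond donors, and these differences cannot be told apart here. No measurement at hand explains the step.

Still open, going by these compounds, is whether a plain butylamino chain without the second amine, or piperidin-1-yl without the ethyl group, would stay closer to compound 2. A carboxylic acid at the end of the chain also remains untested among the compounds shown.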